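From a saturated to an aromatic sulfonyl substituent

This account rests on a few compounds, and the source may have more. Where it says the series, first, only, none or still open, it means among the compounds named here.

Measured in a physicochemical assay for solubility, measured as kinetic solubility, with a stated time of 24 h, at pH 7.4; on this read-out higher numbers stand for higher solubility and lower numbers for lower solubility:
compound 1 `O=C(NCc1ccc(S(=O)(=O)c2cc(F)cc(F)c2)cc1)c1cc2ccncc2o1`: 5900 nM
compound 2 `O=C(NCc1ccc(S(=O)(=O)N2CCOCC2)cc1)c1cc2ccncc2o1`: 101000 nM
compound 3 `CC(C)N1CCC(S(=O)(=O)c2ccc(CNC(=O)c3cc4ccncc4o3)cc2)CC1`: 183000 nM

Compound 3 stands at the upper end of this short series, level within the scatter with its nearest neighbour: a 1.8-fold higher number from compound 2 to compound 3 (0.26 log units; within the scatter). The next compound, compound 4 `CC(C)n1cc(S(=O)(=O)c2ccc(CNC(=O)c3cc4ccncc4o3)cc2)cn1`, has not yet been measured. It carries 1-isopropyl-1H-pyrazol-4-yl in place of 1-isopropylpiperidin-4-yl on a sulfonyl sulfur.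

Among the measured compounds shown here, two measured steps bear on this change, and both are large. Each leaves the aromatic 3,5-difluorophenyl: a 17-fold higher number from compound 1 to compound 2 (1.23 log units; beyond the scatter) and a 31-fold higher number from compound 1 to compound 3 (1.49 log units; beyond the scatter). Compound 4 also has an aromatic ring at that place, so a clear fall from the value of compound 3 is expected in this assay. For the measured compounds named here, no measured compound carries this ring, however, so the fall is expected to stop short of the full distance to compound 1. The expected step is a 6.1-fold lower number from compound 3 to compound 4 (0.79 log units; beyond the scatter). For compound 4 the estimate is 30000 nM, with an expected range of 8000 nM to 100000 nM.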

Compound 4, solubility: 12000 nM
The estimate for compound 4 lay 2.5-fold (0.40 log units) above the measured number; low and high end bracket the measured number.
By their numbers in this assay, from the lowest: compound 1; then compound 4; then compounds 2 and 3 (each within the scatter of the next).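

In this assay, the aromatic 1-isopropyl-1H-pyrazol-4-yl on the sulfonyl sulfur behaves much more like the aromatic 3,5-difluorophenyl than like either non-aromatic ring, with only a 2.0-fold higher number from compound 1 to compound 4 (0.31 log units; beyond the scatter) set against a 15-fold lower number from compound 3 to compound 4 (1.18 log units; beyond the scatter) and an 8.4-fold lower number from compound 2 to compound 4 (0.93 log units; beyond the scatter). The isopropyl group is present in both compound 3 and compound 4, so the large step between them goes with the change of ring and not with the loss of that group. Across these compounds the two aromatic rings give the lower numbers and the two non-aromatic rings the higher ones, and no compound shown goes against this.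

On these data alone, whether a pyridine ring, or a pyrazole carrying an amine in place of isopropyl, would stand nearer compound 3 remains open. The data shown offer no explanation for the size of these steps.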